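From propoxy to isopropoxy: an estimate for compound 3

The source may report more compounds than this note shows. Statements on the series, on what has been measured and on what is new or still open speak of the compounds shown alone.

Measured so far in a functional assay on corpus cavernosum (Rattus norvegicus) for activation; on this read-out lower numbers stand for an effect already at smaller amounts and higher numbers for an effect only at larger amounts of compound
- compound 1 (`CC(C)Oc1ccccc1-c1nc2c(cnn2-c2ccccc2)c(=O)[nH]1`) gives 500 nM
- compound 2 (`CCCOc1ccccc1-c1nc2c(cnn2-c2ccc(Br)cc2)c(=O)[nH]1`) gives 830 nM

On these numbers, compound 2 stands within the scatter of compound 1, so the two values cannot be told apart. The next compound, compound 3 (`CC(C)Oc1ccccc1-c1nc2c(cnn2-c2ccc(Br)cc2)c(=O)[nH]1`), has the same atoms as compound 2, joined differently. It carries isopropyl in place of propyl on an oxygen on an aromatic ring. Going by the values given here, no two measured compounds differ in one place only, so the data give no direct measure of this change. The nearest guide is compound 1 (500 nM), which also carries isopropoxy and lies within the scatter of compound 2 (830 nM). On that basis, only a small move toward a lower number is expected in this assay, and none beyond the scatter. The expected change is (a 1.4-fold lower number from compound 2 to compound 3 (0.14 log units; within the scatter)) and rests on very little evidence. For compound 3 the estimate is 600 nM as the expected value, with an expected range from 200 nM to 1800 nM in this reading.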

Compound 3, half-maximal effective concentration: 280 nM
Compound 3: the middle estimate sits 2.1-fold (0.33 log units) above what was measured, and the stated range covers the measured number.
By their numbers in this assay, from the lowest: compounds 3, 1 and 2 (each within the scatter of the next, the first and the last beyond it).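

In this assay, going by these compounds alone, putting isopropyl in place of propyl on an oxygen on an aromatic ring, with nothing else altered, gives a 3.0-fold lower number from compound 2 to compound 3 (0.47 log units; beyond the scatter); this is the first direct reading at this position, and it shows that the assay can respond to how the same atoms of this side chain are joined. The other single change, bromo in place of hydrogen on an aromatic carbon with isopropoxy held fixed, gives a 1.8-fold lower number from compound 1 to compound 3 (0.25 log units; within the scatter), so in this one pair the effect of the bromo cannot be told apart from repeat measurement. Nothing available explains why the isopropyl change has a larger effect than the bromo change.

The compounds shown cover only propyl and isopropyl on this oxygen, so it remains open how a longer chain such as butyl, or a ring such as cyclopropyl, would read in this assay. As far as these compounds go, each change also rests on a single pair, so it is unknown whether the isopropyl step holds on a core with hydrogen in place of bromo, or how chloro or an amine would read in the place of the bromo.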